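This account rests on a few compounds, and the source may have more. Where it says the series, first, only, none or still open, it means among the compounds named here.

The measured compounds in a functional assay on UACC-257 cells (Homo sapiens) for cytotoxicity, read by sulforhodamine B assay, with a stated time of 48 h (a lower number here means a stronger inhibitor of growth, a higher number a weaker inhibitor of growth), are these:

compound 1, `ClCc1ccc(Cn2cnc3c(Cl)ncnc32)cc1`, which gives 7410 nM
compound 2, `Nc1nc(Cl)c2ncn(Cc3ccc(CCl)cc3)c2n1`, which gives 12600 nM
compound 3, `ClCc1ccccc1Cn1cnc2c(Cl)ncnc21`, which gives 10700 nM

Compound 1 and compound 2 share a core and differ in one place:

amino in place of hydrogen on an aromatic carbon

This change brought a 1.7-fold higher number from compound 1 to compound 2 (0.23 log units; within the scatter).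

Compound 3 is built from the same atoms as compound 1, joined differently; the difference between the two cores is not broken down here. Compound 3 gives 10700 nM in this assay, and this value and those of compound 1 and compound 2 all lie within the scatter of one another.

Compound 4, `Nc1nc(Cl)c2ncn(Cc3ccccc3CCl)c2n1`, has not been measured. It differs from compound 3 as follows:

amino in place of hydrogen on an aromatic carbon

This is the same change that was made from compound 1 to compound 2, at the same kind of place. Because the earlier step was a 1.7-fold higher number from compound 1 to compound 2 (0.23 log units; within the scatter), a step of similar size is expected here, a 1.5-fold higher number from compound 3 to compound 4 (0.17 log units; within the scatter). Compound 4 is therefore expected to give about 16000 nM in this assay, with a plausible range from 7000 nM to 40000 nM.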

Compound 4, concentration for 50% growth inhibition: 13200 nM
Compound 4: the middle estimate sits 1.2-fold (0.08 log units) above what was measured; low and high end bracket the measured number.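

In this assay, amino in place of hydrogen on an aromatic carbon brought a 1.2-fold higher number from compound 3 to compound 4 (0.09 log units; within the scatter). Set beside the earlier case, the two steps do not differ beyond what repeated measurement would give: the same change on two cores in this assay, a 1.7-fold higher number (0.23 log units; within the scatter) from compound 1 to compound 2 and a 1.2-fold higher number (0.09 log units; within the scatter) from compound 3 to compound 4, 1.4-fold (0.14 log units) apart, within the scatter of two such steps. This shows that the change carried from the core of compound 1 to the core of compound 3 with no detectable difference in the size of its step, but it does not show that amino has any real effect on growth inhibition in this series, as each step on its own lies within the scatter, and two cores cannot show that the change would behave alike on a third.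

The compounds shown leave open what other groups would give at this same place, such as a methylamino group, a hydroxyl or a methoxy group. They also leave open what would follow if the chloro group gave way to an amine or a longer chain.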